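This account rests on a few compounds, and the source may have more. Where it says the series, first, only, none or still open, it means among the compounds named here.

Measured compounds:
Compound 1 `CCOC(=O)c1c(-c2cccc(OC(C)C)c2)[nH]c2cc(OC)ccc2c1=O` gives > 22000 nM in an ADME assay on HEK293 cells (Homo sapiens) for cytotoxicity, read by luminescence, with a stated time of 72 h (on this read-out higher numbers stand for an effect only at larger amounts of compound and lower numbers for an effect already at smaller amounts), which is a limit of the assay and not a number.
Compound 2 `CCOC(=O)c1c(-c2cccc(Cl)c2)[nH]c2cc(OC)ccc2c1=O` gives > 22000 nM in this assay, again a limit rather than a number.
Compound 3 `CCOC(=O)c1c(-c2cccc(Br)c2)[nH]c2cc(OC)ccc2c1=O` gives > 22000 nM in this assay, also a limit.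

Compound 1 thus stands only at a limit in this assay, and nothing more precise is known of it. Compound 4 `CCOC(=O)c1c(-c2cccc(N(C)C)c2)[nH]c2cc(OC)ccc2c1=O` differs from compound 1 by dimethylamino in place of isopropoxy on an aromatic carbon. The measured steps that bear on replacing the isopropoxy group are a step that the two limits leave unreadable from compound 1 to compound 2 and a step that the two limits leave unreadable from compound 1 to compound 3; both begin and end at the limit, so their size cannot be read. The same holds for a step that the two limits leave unreadable from compound 2 to compound 3. Going by the values given here, with every value sitting at the limit of > 22000 nM in this assay, at which 3 of the 3 values shown sit, no step of readable size is available, and the expectation for compound 4 is that it too reaches only the limit, with no step beyond the scatter. Compound 4 is therefore estimated at 30000 nM, within 15000 nM to 100000 nM. That estimate means an expected step that the limit leaves unreadable from compound 1 to compound 4, which is taken to be no more than the usual scatter.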

Compound 4, half-maximal effective concentration: > 22000 nM
Compound 4: a limit, no number; the forecaster's own chance of this, stated with the estimate: 80%; the middle value is on the limit's open side.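

Compound 4 gives > 22000 nM in this assay, which is a limit and not a number. The steps linking compound 4 with compound 1, compound 2 and compound 3 therefore cannot be read: the limit of > 22000 nM in this assay, at which 4 of the 4 values shown sit. The compounds shown leave open what true values lie beyond this limit, and whether these four compounds differ at all in this assay.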